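Hydroxy in place of oxazolyl on the amide nitrogen

The compounds below may be only part of what the source reports. "The series", "measured", "known", "first", "only" and "open" are said of these compounds alone.

Measured compounds:
compound 1 `Cc1ccc(OCC(=O)N(Cc2cccs2)C2CCCCC2)cc1` — 40000 nM
compound 2 `Cc1ccc(OCC(=O)N(Cc2cccs2)C2CC2)cc1` — 8 nM
compound 3 `Cc1ccc(OCC(=O)N(Cc2cccs2)c2ncco2)cc1` — 0.3 nM

In an assay on HEK293 cells for agonist activity at transient receptor potential cation channel subfamily M member 8 (Homo sapiens), read by fluorescence and calcium flux, with a stated time of 15 min (a higher number here means that more compound is needed for the effect, a lower number that less compound is needed), compound 3 stands lowest of the three, with compound 2 nearest and compound 1 furthest, as the steps of a 27-fold lower number from compound 2 to compound 3 (1.43 log units; beyond the scatter) and a 130000-fold lower number from compound 1 to compound 3 (5.12 log units; beyond the scatter) show. Compound 4 `Cc1ccc(OCC(=O)N(O)Cc2cccs2)cc1` differs from compound 3 in one place: hydroxy in place of 1,3-oxazol-2-yl on an amide-type nitrogen. Every measured step bears on this position, and each was large: a 5000-fold lower number from compound 1 to compound 2 (3.70 log units; beyond the scatter), a 130000-fold lower number from compound 1 to compound 3 (5.12 log units; beyond the scatter), a 27-fold lower number from compound 2 to compound 3 (1.43 log units; beyond the scatter). Among the compounds with values here, no measured compound carries a hydroxy or any non-ring group there, so the direction rests on weak ground; since the ring of compound 3 goes, a higher number is expected for compound 4, estimated at 150 nM within 5 nM to 5000 nM, a step of a 500-fold higher number from compound 3 to compound 4 (2.70 log units; beyond the scatter).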

Compound 4, half-maximal effective concentration: 8000 nM
Compound 4: middle estimate off by 53-fold (1.73 log units), on the low side; measured number outside the range, above it.
By their numbers in this assay, from the lowest: compound 3; then compound 2; then compound 4; then compound 1.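

Within the data shown here, with hydroxy on the amide-type nitrogen, the first non-ring group at this position, the number rises steeply against both lower compounds, by a 27000-fold higher number from compound 3 to compound 4 (4.43 log units; beyond the scatter) and by a 1000-fold higher number from compound 2 to compound 4 (3.00 log units; beyond the scatter). Yet the group with a single heavy atom does not match cyclopropyl and stays near the cyclohexyl end of the series, with only a 5.0-fold lower number from compound 1 to compound 4 (0.70 log units; beyond the scatter), so the number does not simply fall as the group shrinks. No measurement given accounts for these differences. On these data alone, whether a methoxy group, an amine or a longer chain here would behave like hydroxy remains open.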